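A few compounds are considered here, and "the series" means these few. Any claim that something is new, unique, unknown or untested is made for them only; others in the source may bear on it.

Measured so far in an in vitro ADME assay on microsomes from liver (Homo sapiens) for metabolic stability; on this read-out higher numbers stand for a longer-lived compound and lower numbers for a shorter-lived compound:
- compound 1 `C[C@@H](c1ccc(Cl)cc1)N1Cc2cncn2C(CC2(C)COC2)S1(=O)=O`: 1.27 h
- compound 2 `CC(C)CC1n2cncc2CN(CC2CC2)S1(=O)=O`: 0.917 h

Compound 1 holds the higher of the two numbers, but its value and that of compound 2 lie within the scatter of each other, so no order between them can be read from this assay. For the measured compounds named here, both share the same core; they differ in more than one place, and no single step between measured compounds has been recorded.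

Compound 3 `C[C@@H](c1ccc(Cl)cc1)N1Cc2cncn2C(C[C@H](O)c2ccccc2)S1(=O)=O` is still to be measured. Against compound 1 the change is hydroxy(phenyl)methyl in place of 3-methyloxetan-3-yl on a saturated chain carbon bound to a saturated ring carbon. Going by the values given here, no measured pair in this set covers such a change, so nothing sets the direction. The working expectation is a step of a 1.4-fold lower number from compound 1 to compound 3 (0.15 log units; within the scatter), that is, no change beyond the scatter. For compound 3 the estimated value in this assay is 0.9 h, with a range from 0.4 h to 2 h.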

Compound 3, half-life: 0.25 h
For compound 3 the middle estimate is 3.6-fold (0.56 log units) above the measured one, and the stated range ends above it.
By their numbers in this assay, from the lowest: compound 3; then compounds 2 and 1 (each within the scatter of the next).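

In this assay, the saturated chain carbon bound to a saturated ring carbon now proves sensitive to substitution: hydroxy(phenyl)methyl in place of 3-methyloxetan-3-yl gives a 5.1-fold lower number from compound 1 to compound 3 (0.71 log units; beyond the scatter). This single change brings in a six-membered aromatic ring of carbon only, a hydrogen-bond donor and a defined stereocentre together, and removes the four-membered non-aromatic ring, so the step belongs to the exchange as a whole and not to any one of these features. No supporting measurement bears on the cause of the step.

The compounds shown do not separate the contribution of the hydroxy group from that of the phenyl ring, which a plain 2-phenylethyl chain or a 2-hydroxypropyl chain at this place would address. As far as these compounds go, the effect of a methoxy group in place of the hydroxy group, or of the opposite configuration at the hydroxy-bearing carbon, also remains open.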